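Thiophene attachment point on a shared dihydropyrimidinone core

The compounds below may be only part of what the source reports. "The series", "measured", "known", "first", "only" and "open" are said of these compounds alone.

Of the compounds shown here, three sharing one core have been tested in an assay on HeLa cells for displacement of a labelled ligand from adenosine receptor A3 (Homo sapiens), read by radioligand binding, with a stated time of 180 min, tested at 1 uM; a lower number here means less inhibition, a higher number more inhibition at the concentration tested (going by the name of the read-out). Compound 1 `CC(C)OC(=O)C1=C(C(F)(F)F)NC(=O)NC1c1ccsc1` gives 3%. Compound 2 `CCOC(=O)C1=C(C(F)(F)F)NC(=O)NC1c1ccsc1` gives 3%, and the change from compound 1 to compound 2 no change at the digits printed from compound 1 to compound 2 (within the scatter) shows nothing beyond the usual scatter. Compound 3 `CC1=C(C(=O)OC(C(F)(F)F)C(F)(F)F)C(c2cccs2)NC(=O)N1` differs from compound 2 in several places. In this assay compound 3 gives 1%. For the measured compounds named here, compound 2 therefore sits level with compound 1 on the numbers so far, and all three values lie together within the scatter of one another.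

The next compound, compound 4 `CCOC(=O)C1=C(C(F)(F)F)NC(=O)NC1c1cccs1`, differs from compound 2 only in the attachment point of the thiophene ring: thiophen-2-yl in place of thiophen-3-yl on a saturated ring carbon. Going by the values given here, no measured step changes this ring alone. Among the compounds with values here, the one measured step, from compound 1 to compound 2, altered the ester and moved nothing, and compound 3, which also carries the thiophen-2-yl, sits at the same low level. Compound 4 is therefore expected to remain near the others, a step of no change at the digits printed from compound 2 to compound 4 (within the scatter) of essentially nothing beyond scatter, estimated at 3% with a range from -7% to 13%.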

Compound 4, a percentage reported as inhibition, at one concentration (the size of the read-out at that concentration, not a potency): 1%
The estimate for compound 4 lay 2 percentage points above the measured number, and the stated range covers the measured number.
By their numbers in this assay, from the lowest: compounds 3, 4, 1 and 2 (each within the scatter of the next).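

Placing thiophen-2-yl instead of thiophen-3-yl on the saturated ring carbon gives the first reading of the attachment point alone: in this assay the swap gives a number 2 percentage points lower from compound 2 to compound 4 (within the scatter) and so shows no readable effect of the attachment point at this level of inhibition. The earlier compounds shown here could not show this, as compound 3 also carries thiophen-2-yl but differs from compound 2 in several places. No measurement at hand accounts for the two thiophenes reading alike.

On these data alone, it remains open whether any other group on this ring carbon, such as a phenyl ring bearing an amine, would give clear inhibition at the concentration tested. Also open, as far as these compounds go, is how a carboxylic acid or a longer chain in place of the ethoxycarbonyl group would read with thiophen-2-yl present.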